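Cytotoxicity of a hydrazone series: from compound 3 to compound 4

This account rests on a few compounds, and the source may have more. Where it says the series, first, only, none or still open, it means among the compounds named here.

Measured compounds in an ADME assay on HEL cells (Homo sapiens) for cytotoxicity; a lower number here means that less compound is tolerated, a higher number that more compound is tolerated:
- compound 1 `O=C(COc1cccc2ccccc12)N/N=C/c1ccccc1[N+](=O)[O-]` gives 100 ug/mL
- compound 2 `O=C(COc1cccc2ccccc12)N/N=C/c1cccc(O)c1` gives 62.7 ug/mL
- compound 3 `O=C(COc1cccc2ccccc12)N/N=C/c1ccccc1Cl` gives 62.7 ug/mL

All three share the same core and differ only in the aromatic ring attached to the carbon with a double bond to nitrogen. Compound 3 shares its number with compound 2, and the step of a 1.6-fold lower number from compound 1 to compound 3 (0.20 log units; within the scatter) is small, so the whole spread of the three numbers lies within the scatter.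

Compound 4 `O=C(COc1cccc2ccccc12)N/N=C/c1cccc(Br)c1` has not yet been measured in this assay. Its change from compound 3 is 3-bromophenyl in place of 2-chlorophenyl on a carbon with a double bond to nitrogen. Among the compounds with values here, two measured steps bear on it. The step of no change at the digits printed from compound 2 to compound 3 (within the scatter) exchanged the whole aromatic ring, including its substituent, without effect. The step of a 1.6-fold lower number from compound 1 to compound 3 (0.20 log units; within the scatter) swapped one substituent for another, again within the scatter. Neither gives a reason to expect movement, so the expected step for compound 4 is a 1.0-fold higher number from compound 3 to compound 4 (0.00 log units; within the scatter), none beyond the scatter. Compound 4 is estimated at 63 ug/mL, with a range from 35 ug/mL to 110 ug/mL.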

Compound 4, half-maximal cytotoxic concentration: 48.6 ug/mL
Beside the measured number, compound 4's estimate is 1.3-fold (0.11 log units) above it; low and high end bracket the measured number.
By their numbers in this assay, from the lowest: compounds 4, 2, 3 and 1 (each within the scatter of the next, the first and the last beyond it).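

In this assay, the step of a 1.3-fold lower number from compound 3 to compound 4 (0.11 log units; within the scatter) replaces 2-chlorophenyl with 3-bromophenyl on the carbon with a double bond to nitrogen, so the halogen and its place on the ring change together, yet the number stays within the scatter. The step of a 1.3-fold lower number from compound 2 to compound 4 (0.11 log units; within the scatter) is also within the scatter, and it adds bromo to the substituents on this ring that leave the number within the scatter of compound 2. No outside measurement bears on why these numbers sit where they do.

With both halogen and place changing in one step, the compounds shown cannot separate the two, as neither 3-chlorophenyl nor 2-bromophenyl is among them. From the compounds shown here alone, whether an amine, a carboxylic acid or a longer chain on this ring would move the number beyond the scatter also stays open.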